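From Methyl to Methoxy: an Estimate for Compound 3

The compounds below may be only part of what the source reports. "The series", "measured", "known", "first", "only" and "open" are said of these compounds alone.

Compound 1 `C#CCSc1nc(Nc2ccc(C)cc2)c2ccncc2n1`: 6170 nM
Compound 2 `C#CCSc1nc(Nc2cccc(Cl)c2)c2ccncc2n1`: 1090 nM

In a functional assay on HepG2 cells (Homo sapiens) for inhibition, read by MTT assay, with a stated time of 72 h (on this read-out lower numbers stand for stronger inhibition and higher numbers for weaker inhibition), compound 1 stands highest of the two numbers measured; compound 2 sits below it, a 5.7-fold lower number from compound 1 to compound 2 (0.75 log units; beyond the scatter). Compound 3 `C#CCSc1nc(Nc2ccc(OC)cc2)c2ccncc2n1` differs from compound 1 in one place: methoxy in place of methyl on an aromatic carbon. For the measured compounds named here, the single measured step swaps the group and its place at once, so it does not bear on this change, and no measured pair separates methoxy from methyl at the same place. The change is therefore expected to stay within the scatter, a 1.2-fold lower number from compound 1 to compound 3 (0.09 log units; within the scatter). Compound 3 is estimated at 5000 nM, with a range from 2000 nM to 15000 nM.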

Compound 3, half-maximal inhibitory concentration: > 80000 nM
Compound 3 gave a limit, no number; the forecaster's own chance of this, stated with the estimate: 5%; at least 16-fold (1.20 log units) between middle value and limit.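

Compound 3 gave a limit of the assay, not a number: the limit of > 80000 nM in this assay, at which 1 of the 3 values shown sits. Even so, replacing methyl with methoxy at this place, para to a large group, produces an at least 12-fold higher number from compound 1 to compound 3 (1.11 log units; beyond the scatter). The earlier step changed the group and its place at once, whereas this one shows that changing the group alone can shift the read-out in this assay well beyond the scatter.

Going by these compounds, it remains open whether a hydroxyl group or an amine at this place would stay close to compound 1 or follow compound 3. On these data alone, whether methoxy would have the same effect at the place that carries chlorine in compound 2 is also open.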